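Amide capping of a nitrobenzofurazan acid

The source may report more compounds than this note shows. Statements on the series, on what has been measured and on what is new or still open speak of the compounds shown alone.

The series rests on a shared core carrying a nitro group and a six-carbon chain ending in a succinate ester. For the measured compounds named here, compound 1 `O=C(O)CCC(=O)OCCCCCCSc1ccc([N+](=O)[O-])c2nonc12` is the free acid; in an ADME assay on HUVEC cells (Homo sapiens) for cytotoxicity, read by MTT assay, with a stated time of 72 h (a lower number here means a stronger inhibitor, a higher number a weaker inhibitor), compound 1 gives 740 nM, the lowest of the two numbers measured so far. Compound 2 `CN(C)CCNC(=O)CCC(=O)OCCCCCCSc1ccc([N+](=O)[O-])c2nonc12` replaces the hydroxy with a (2-(dimethylamino)ethyl)amino group, and in this assay compound 2 gives 2160 nM; the step of a 2.9-fold higher number from compound 1 to compound 2 (0.47 log units; beyond the scatter) is modest but beyond the scatter.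

Compound 3 `O=C(CCC(=O)N1CCOCC1)OCCCCCCSc1ccc([N+](=O)[O-])c2nonc12` is the unmeasured analogue. Its difference from compound 1 is morpholin-4-yl in place of hydroxy on a carbonyl carbon. Going by the values given here, the only step that bears on it is the one from acid to amide already seen, a 2.9-fold higher number from compound 1 to compound 2 (0.47 log units; beyond the scatter), in which the carboxy became a carboxamide of a different kind. Since the change to compound 3 likewise converts the carboxy to a (morpholin-4-yl)carbonyl, a rise in this assay of a similar, modest size is expected, in the direction of a higher number. On that basis compound 3 is estimated at 2000 nM, with a range from 900 nM to 4500 nM, corresponding to an expected step of a 2.7-fold higher number from compound 1 to compound 3 (0.43 log units; beyond the scatter).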

Compound 3, half-maximal inhibitory concentration: 5340 nM
Compound 3: middle estimate off by 2.7-fold (0.43 log units), on the low side; the whole stated range lies below it.
By their numbers in this assay, from the lowest: compound 1; then compound 2; then compound 3.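

At this carbonyl carbon, the size of the rise depends on which group replaces the hydroxy: in this assay, the morpholin-4-yl group gives a 7.2-fold higher number from compound 1 to compound 3 (0.86 log units; beyond the scatter), and exchanging the (2-(dimethylamino)ethyl)amino group for it gives a 2.5-fold higher number from compound 2 to compound 3 (0.39 log units; beyond the scatter), also beyond the scatter. The two amides are therefore not interchangeable at this position, although both give higher numbers than the free acid, compound 1, and no compound goes against that order among the three shown. No measurement is available that would account for the gap between compound 2 and compound 3.

The compounds shown leave open whether the higher number of compound 3 belongs to the ring as a whole or to its oxygen, a question that a piperidin-1-yl or 4-methylpiperazin-1-yl amide at the same carbonyl carbon would help to separate. They also leave open how a simple amine-derived amide such as dimethylamino, or a shorter or longer chain in place of the six-carbon chain, would read in this assay.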